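Hydroxymethylpropyl Amide Replacing Cyclopentyl in Compound 4

The compounds below may be only part of what the source reports. "The series", "measured", "known", "first", "only" and "open" are said of these compounds alone.

Compound 3 `COc1cccc2cc(C(=O)NC3CCCC3)c(=N)oc12` carries a cyclopentyl on its amide nitrogen. In an assay on CHO cells for displacement of a labelled ligand from adenosine receptor A1 (Homo sapiens), read by scintillation counting, with a stated time of 60 min, tested at 10 uM (on this read-out higher numbers stand for more inhibition at the one concentration tested (going by the name of the read-out) and lower numbers for less inhibition), compound 3 gives > 70%, which is a limit of the assay rather than a number. Compound 1 `COCCNC(=O)c1cc2cccc(OC)c2oc1=N` likewise gives only a limit, > 70%, in this assay. Compound 2 `COc1cccc2cc(C(=O)NCCO)c(=N)oc12` gives 47% in this assay. Compound 4 `CCC(CO)NC(=O)c1cc2cccc(OC)c2oc1=N` has not yet been measured; it differs from compound 3 by 1-(hydroxymethyl)propyl in place of cyclopentyl on an amide-type nitrogen. The closest measured comparison is a number at least 23 percentage points higher from compound 2 to compound 3 (beyond the scatter), whereas a step that the two limits leave unreadable from compound 1 to compound 3. Since compound 3 sits at the limit (the limit of > 70% in this assay, at which 2 of the 3 values shown sit), the change expected for compound 4 is a moderate drop in inhibition, a number at least 15 percentage points lower from compound 3 to compound 4 (beyond the scatter). Compound 4 is therefore estimated to give 55% in this assay, within a range from 30% to 80%.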

Compound 4, a percentage reported as inhibition, at one concentration (the size of the read-out at that concentration, not a potency): 24%
The estimate for compound 4 lay 31 percentage points above the measured number, and the stated range ends above it.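

In this assay the number falls with 1-(hydroxymethyl)propyl on the amide nitrogen, which gives a number at least 46 percentage points lower from compound 3 to compound 4 (beyond the scatter) and, against 2-methoxyethyl, a number at least 46 percentage points lower from compound 1 to compound 4 (beyond the scatter). Adding ethyl to the chain of compound 2 brings no recovery either, giving a number 23 percentage points lower from compound 2 to compound 4 (beyond the scatter). On these data alone, the two larger steps start from a limit, so their full size stays unknown: the limit of > 70% in this assay, at which 2 of the 4 values shown sit.

The compounds shown do not separate the branch from the free hydroxyl. A 1-(methoxymethyl)propyl group on the amide nitrogen would bear on that, as would an amine in place of the hydroxyl.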